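Triazole dithiocarbamates: ring-to-nitrogen substituent swap on compound 2

This account rests on a few compounds, and the source may have more. Where it says the series, first, only, none or still open, it means among the compounds named here.

Of the compounds shown here, two have numbers so far. Compound 1 `Fc1ccccc1Cn1cc(CSC(=S)N2CCNCC2)nn1` gives 33200 nM in a functional assay on MCF7 cells (Homo sapiens) for inhibition, read by MTT assay, with a stated time of 72 h; on this read-out lower numbers stand for stronger inhibition and higher numbers for weaker inhibition. Compound 2 `CC(C)(C)OC(=O)N1CCN(C(=S)SCc2cn(-c3ccccc3F)nn2)CC1` gives 89600 nM in this assay, the highest of the two numbers; its nearest neighbour is compound 1, whose number is lower by a margin beyond the usual scatter. Within the data shown here, compound 1 and compound 2 differ in more than one place, so no single step between them can be read.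

Compound 3 `CC(C)(C)OC(=O)N1CCN(C(=S)SCc2cn(Cc3ccc(Cl)cc3)nn2)CC1` is not yet measured. It differs from compound 2 in one place: 4-chlorobenzyl in place of 2-fluorophenyl on an aromatic nitrogen. Among the measured compounds shown here, no measured pair shows this change, so its effect rests on expectation alone. A modest step toward lower numbers is expected, likely at the edge of the scatter, and the step from compound 2 to compound 3 is estimated as a 1.8-fold lower number from compound 2 to compound 3 (0.25 log units; within the scatter). Compound 3 is accordingly expected to give about 50000 nM in this assay, within a range of 20000 nM to 120000 nM.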

Compound 3, half-maximal inhibitory concentration: 2960 nM
Estimate against measurement, compound 3: 17-fold (1.23 log units) above, outside the stated range (below it).
By their numbers in this assay, from the lowest: compound 3; then compound 1; then compound 2.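

Among these compounds, the aromatic nitrogen of the five-membered ring is the first position where a single change can be read, and it matters strongly: in this assay, 4-chlorobenzyl in place of 2-fluorophenyl gives a 30-fold lower number from compound 2 to compound 3 (1.48 log units; beyond the scatter). This one swap alters several things at once, as chlorine replaces fluorine and benzyl replaces phenyl, so the step cannot be assigned to either alone. Nothing available accounts for the size of this step.

Still open, as far as these compounds go, is which part of the swap carries the step, a question that a plain benzyl or a 4-chlorophenyl on the same nitrogen of compound 3 would address. Steps from compound 1 to the other two compounds cannot be read, as it differs from each in more than one place.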